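This account rests on a few compounds, and the source may have more. Where it says the series, first, only, none or still open, it means among the compounds named here.

Series notes. Compound 1 `COc1ccccc1C(=O)NC(=S)Nc1ccc(N2CCCCC2)c(Cl)c1`, compound 2 `COc1ccccc1C(=O)NC(=O)Nc1ccc(-c2nccs2)c(C(F)(F)F)c1` and compound 3 `COc1ccncc1C(=O)NC(=O)Nc1ccc(-c2ccccc2)c(C(F)(F)F)c1` share the acyl-urea-type core with a substituted aryl on one side, and all three have been run in an in vitro ADME assay on microsomes from liver (Rattus norvegicus) for metabolic stability, with a stated time of 30 min; on this read-out lower numbers stand for slow clearance and higher numbers for fast clearance. In this assay compound 1 gives 29 mL.min-1.g-1 and compound 2 gives 33 mL.min-1.g-1; these two numbers lie within the scatter of one another, so no order between them can be read. For compound 3 this assay returns a limit of < 14 mL.min-1.g-1, not a number, so it only marks where the read-out stops (the limit of < 14 mL.min-1.g-1 in this assay, at which 1 of the 3 values shown sits). Among the numbers shown, compound 2 thus sits level with compound 1, and the third entry is a limit.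

Compound 4 `COc1ccccc1C(=O)NC(=O)Nc1ccc(OCC(F)(F)F)c(C(F)(F)F)c1` is not yet measured in this assay. It differs from compound 2 in one place: 2,2,2-trifluoroethoxy in place of 1,3-thiazol-2-yl on an aromatic carbon. Within the data shown here, no step between two measured compounds isolates this change, so its size is open. Given that compound 2 gives 33 mL.min-1.g-1 and compound 1, with a different aryl substitution, gives 29 mL.min-1.g-1, a step from compound 2 to compound 4 of no more than about the scatter is expected, in either direction, a 1.3-fold lower number from compound 2 to compound 4 (0.12 log units; within the scatter). On that basis compound 4 is estimated at 25 mL.min-1.g-1, with a range from 10 mL.min-1.g-1 to 60 mL.min-1.g-1.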

Compound 4, intrinsic clearance in microsomes: 25 mL.min-1.g-1
For compound 4 middle estimate and measured number coincide at the digits printed; measured number inside the range.
By their numbers in this assay, from the lowest: compounds 4, 1 and 2 (each within the scatter of the next). At a limit, below all of these: compound 3.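

In this assay, among these compounds, 2,2,2-trifluoroethoxy in place of 1,3-thiazol-2-yl on an aromatic carbon ortho to a trifluoromethyl group gives a 1.3-fold lower number from compound 2 to compound 4 (0.12 log units; within the scatter), the first step that isolates a single change. At this position, an open chain with no ring and a five-membered aromatic ring with 2 hetero atoms therefore cannot be told apart on this read-out, and the aromatic ring can be exchanged without the number moving beyond the scatter. Nothing shown gives a cause for this step.

Going by these compounds, whether any group at this position moves the number beyond the scatter stays open, since a primary amine, a carboxylic acid or a longer fluoroalkoxy chain does not appear among the compounds here, and this single step cannot say whether the same holds on a different core. Compound 3 carries only a limit, and steps to it cannot be read: the limit of < 14 mL.min-1.g-1 in this assay, at which 1 of the 4 values shown sits.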